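Aryl substituent change at the pyrazole nitrogen aryl group

The compounds below may be only part of what the source reports. "The series", "measured", "known", "first", "only" and "open" are said of these compounds alone.

Measured so far:
compound 1 `O=C(NCc1cc(C(F)(F)F)nn1-c1ccc(Cl)cc1)Nc1cccc2[nH]ncc12` gives 2.5 nM in an assay on CHO-K1 cells for antagonist activity at transient receptor potential cation channel subfamily V member 1 (Homo sapiens), read by FLIPR and calcium flux, with a stated time of 6 min; on this read-out lower numbers stand for stronger inhibition and higher numbers for weaker inhibition
compound 2 `O=C(NCc1cc(C(F)(F)F)nn1-c1ccc(C(F)(F)F)cc1)Nc1cccc2[nH]ncc12` gives 3.8 nM in this assay

Compound 2 holds the highest of the two numbers measured, and its nearest neighbour is compound 1, which lies a 1.5-fold higher number from compound 1 to compound 2 (0.18 log units; within the scatter) away; the two are within the scatter of each other, so no order between them can be read.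

Compound 3 `CC(C)c1ccc(-n2nc(C(F)(F)F)cc2CNC(=O)Nc2cccc3[nH]ncc23)cc1` is not yet measured. It differs from compound 2 by isopropyl in place of trifluoromethyl on an aromatic carbon.

Within the data shown here, the only measured step that bears on this position is the one from compound 1 to compound 2, a 1.5-fold higher number from compound 1 to compound 2 (0.18 log units; within the scatter), a change of one group for another on the same aromatic carbon, para to a large group, that left the number within the scatter. Nothing measured tells how an isopropyl behaves there. On that basis a small step is expected for compound 3, a 1.3-fold higher number from compound 2 to compound 3 (0.12 log units; within the scatter), with no direction beyond the scatter that the data would support. Compound 3 is therefore estimated at 5 nM in this assay, with a range from 1.5 nM to 17 nM.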

Compound 3, inhibition constant: 4.1 nM
Compound 3: middle estimate off by 1.2-fold (0.09 log units), on the high side; the measured number falls inside the stated range.
By their numbers in this assay, from the lowest: compounds 1, 2 and 3 (each within the scatter of the next).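

In this assay, the isopropyl group of compound 3 gives a 1.1-fold higher number from compound 2 to compound 3 (0.03 log units; within the scatter) and a 1.6-fold higher number from compound 1 to compound 3 (0.21 log units; within the scatter), so chloro, trifluoromethyl and isopropyl on this aromatic carbon, para to a large group, cannot be put in any order. Among these compounds, the earlier pair compared only two halogen-bearing groups, whereas compound 3 extends the comparison to a group of carbon only, and the number still stays within the scatter of both earlier compounds. No supporting measurement is available to explain why these three groups read alike in this series.

The compounds shown leave open whether this flat reading holds for groups of another kind on the same carbon, such as an amine, a carboxylic acid, a methoxy group or a longer alkyl chain, any of which could mark where the reading begins to move beyond the scatter. They also leave open how the unsubstituted phenyl ring compares, and whether the same groups read alike when placed elsewhere on that ring, as all three compounds carry theirs at this one position.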